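Replacing phenyl with neopentyl in compound 1

A few compounds are considered here, and "the series" means these few. Any claim that something is new, unique, unknown or untested is made for them only; others in the source may bear on it.

Compound 1 `O=C([C@H](O)c1ccccc1)N1CC[C@@H]2C[C@@]21C(=O)NCc1cc(Cl)ccc1-n1cnnn1` gives 2.6 10^-6 cm/s
Compound 2 `O=C(NCc1cc(Cl)ccc1-n1cnnn1)[C@@H]1C[C@H]2C[C@H]2N1C(=O)[C@H](O)c1ccccc1` gives 17 10^-6 cm/s

In an ADME assay on Caco-2 cells (Homo sapiens) for permeability, read by LC-MS, in the apical to basolateral direction, with a stated time of 60 min, at pH 6.5 (a higher number here means that the compound crosses the layer faster, a lower number that the compound crosses the layer more slowly), compound 1 gives 2.6 10^-6 cm/s and is the lower of the two, with a gap to compound 2 that lies beyond the scatter. Compound 3 `CC(C)(C)C[C@@H](O)C(=O)N1CC[C@@H]2C[C@@]21C(=O)NCc1cc(Cl)ccc1-n1cnnn1` has not been measured yet. It keeps the core of compound 1, and the difference is neopentyl in place of phenyl on a saturated chain carbon bound to a carbonyl carbon and an oxygen on a saturated carbon at a saturated chain carbon bound to a carbonyl carbon and an oxygen on a saturated carbon. Among the compounds with values here, no measured pair shows this swap, so only a slight rise, not beyond the scatter, is expected. The expected change is a 1.3-fold higher number from compound 1 to compound 3 (0.13 log units; within the scatter) and no more than that. The estimated value for compound 3 is 3.5 10^-6 cm/s (expected range 1.3 10^-6 cm/s to 9 10^-6 cm/s).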

Compound 3, apparent permeability: 7.8 10^-6 cm/s
For compound 3 the middle estimate is 2.2-fold (0.35 log units) below the measured one; low and high end bracket the measured number.
By their numbers in this assay, from the lowest: compound 1; then compound 3; then compound 2.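

In this assay, within the data shown here, the swap of phenyl for neopentyl, on a saturated chain carbon bound to a carbonyl carbon and an oxygen on a saturated carbon, gives a 3.0-fold higher number from compound 1 to compound 3 (0.48 log units; beyond the scatter) and is the first change at this place that can be read directly. For this pair, the six-membered aromatic ring is not needed at this place to keep the number from falling. No measurement here gives a reason for the rise. From the compounds shown here alone, whether a cyclohexyl, an amine or a longer chain at this place would raise the number further stays open, as does whether the same swap gives a similar step on the core of compound 2.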